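This account rests on a few compounds, and the source may have more. Where it says the series, first, only, none or still open, it means among the compounds named here.

Compound 1 `CCOC(=O)c1cnc(NC2CCCC2)n2nc(-c3ccco3)nc12` gives 4620 nM in a functional assay on CHO cells for antagonist activity at adenosine receptor A2b (Homo sapiens); a lower number here means a stronger inhibitor, a higher number a weaker inhibitor. Compound 2 `CCOC(=O)c1cnc(N2CCCCC2)n2nc(-c3ccco3)nc12` is known in this assay only as a limit, > 10000 nM, not as a number. Its standing is therefore a range at the weak end of what the assay reports. The measured step of an at least 2.1-fold higher number from compound 1 to compound 2 (0.33 log units; beyond the scatter) is itself only a bound because the limit of > 10000 nM in this assay, at which 1 of the 2 values shown sits, caps what is known of compound 2. Compound 3 `CCOC(=O)c1cnc(NCCOC)n2nc(-c3ccco3)nc12` differs from compound 2 by (2-methoxyethyl)amino in place of piperidin-1-yl on an aromatic carbon. The change brings back a hydrogen-bond donor at the place where compound 1 carries cyclopentylamino, so the step of an at least 2.0-fold lower number from compound 2 to compound 3 (0.30 log units; that floor lies within the scatter) is expected to run against the earlier step. Compound 3 is estimated at 5000 nM, with a range from 1500 nM to 16000 nM.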

Compound 3, inhibition constant: > 10000 nM
Compound 3 ended at the assay's limit (the forecaster's own chance of this, stated with the estimate: 35%); middle value at least 2.0-fold (0.30 log units) from the limit.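

In this assay compound 3 is known only as a limit (> 10000 nM). With 2-methoxyethyl in place of cyclopentyl on the nitrogen, the record shows an at least 2.1-fold higher number from compound 1 to compound 3 (0.33 log units; beyond the scatter) and so a hydrogen-bond donor at this place does not by itself hold the level of compound 1. The step between compound 2 and compound 3 cannot be read because both stand at a limit: the limit of > 10000 nM in this assay, at which 2 of the 3 values shown sit. From the compounds shown here alone, how far compound 2 and compound 3 actually lie from compound 1 stays open. So does whether a cyclohexylamino or benzylamino group at this place would match or better compound 1 (4620 nM).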